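Trading the Cyclopropyl for a Methyl on the Side Chain

The source may hold more compounds than are shown below. What is called first, only, known or untested is meant among the compounds shown, and "the series" means these compounds.

Compound 1 `COC[C@H](C1CC1)n1cc(Cl)nc(Nc2cc(C)c(OC)nc2C)c1=O` is tested in an assay on frontal cortex for displacement of a labelled ligand from corticotropin-releasing factor receptor 1 (Rattus norvegicus) (a lower number here means a stronger inhibitor, a higher number a weaker inhibitor), where compound 1 gives 1.5 nM. Two close relatives share its core and differ only in the side chain on the ring nitrogen. In this assay compound 2 `CC[C@H](C1CC1)n1cc(Cl)nc(Nc2cc(C)c(OC)nc2C)c1=O` gives 0.28 nM, and compound 3 `COc1nc(C)c(Nc2nc(Cl)cn([C@H](C)C3CC3)c2=O)cc1C` gives 1.5 nM. Among these three numbers compound 1 sits level with compound 3, the two together being the highest of the three: no change at the digits printed from compound 1 to compound 3 (within the scatter), whereas a 5.4-fold lower number from compound 1 to compound 2 (0.73 log units; beyond the scatter).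

Compound 4 `COC[C@@H](C)n1cc(Cl)nc(Nc2cc(C)c(OC)nc2C)c1=O` has not been measured. It differs from compound 1 in one place: 1-(methoxymethyl)ethyl in place of 1-cyclopropyl-2-methoxyethyl on an aromatic nitrogen. The methoxymethyl arm and the single stereocentre stay; the three-membered ring gives way to a methyl.

Among the compounds with values here, none of the measured steps touches this part of the chain. The steps from compound 1 to compound 2 and from compound 1 to compound 3 vary the methoxymethyl arm while keeping the cyclopropyl, and they show that this side chain can shift the number by a modest amount or leave it unchanged. The cyclopropyl itself is never varied among the measured compounds, so the expectation rests on the size of the steps seen nearby: a modest shift at most, with a loss of the ring judged somewhat more likely to raise the number than to lower it. The estimate for compound 4 is 4 nM, within 1.2 nM to 15 nM, an expected step of a 2.7-fold higher number from compound 1 to compound 4 (0.43 log units; beyond the scatter).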

Compound 4, half-maximal inhibitory concentration: 14 nM
Compound 4: the middle estimate sits 3.5-fold (0.54 log units) below what was measured; the range from low to high includes it.
By their numbers in this assay, from the lowest: compound 2; then compounds 1 and 3 (each within the scatter of the next); then compound 4.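

Within the data shown here, compound 4 is the only compound here without the cyclopropyl, and losing the ring has a clear cost in this assay (a 9.3-fold higher number from compound 1 to compound 4 (0.97 log units; beyond the scatter)), whereas the earlier steps changed only the other arm of the side chain. The same direction appears from the other two neighbours, with methoxymethyl in place of cyclopropyl (a 9.3-fold higher number from compound 3 to compound 4 (0.97 log units; beyond the scatter)) and with 1-(methoxymethyl)ethyl in place of 1-cyclopropylpropyl (a 50-fold higher number from compound 2 to compound 4 (1.70 log units; beyond the scatter)), the largest step in this small set. All three steps that remove the ring raise the number, no compound shown goes against this, and compound 4 is the weakest inhibitor of the four, so the cyclopropyl matters more here than the methoxymethyl arm, whose removal from compound 1 left the number unchanged within the scatter.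

No measurement shown gives a reason for the size of these steps. Going by these compounds, it remains open whether a three-membered ring is specifically needed or whether another carbon group on the same chain carbon, such as a cyclobutyl or a longer chain, would hold the number as low as compound 2 does.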